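The source may report more compounds than this note shows. Statements on the series, on what has been measured and on what is new or still open speak of the compounds shown alone.

Among the measured compounds shown here, compound 2 `CCCN(Cc1c(C(F)(F)F)nc2n(-c3c(C)cc(C)cc3C)c(Cl)cn12)CC1CCC1` is the stronger of the two compounds measured so far in an assay on cells for displacement of a labelled ligand from corticotropin-releasing factor receptor 1 (Homo sapiens), with a stated time of 100 min; on this read-out lower numbers stand for stronger inhibition and higher numbers for weaker inhibition: compound 2 gives 5.3 nM, while compound 1 `Cc1cc(C)c(-n2c(Cl)cn3c(CN(CCC(F)(F)F)CC4CC4)c(C(F)(F)F)nc23)c(C)c1` gives 16 nM, and the change a 3.0-fold lower number from compound 1 to compound 2 (0.48 log units; beyond the scatter) lies beyond the scatter. Compound 3 `CCN(Cc1c(C(F)(F)F)nc2n(-c3c(C)cc(C)cc3C)c(Cl)cn12)CC1CCC1` differs from compound 2 by hydrogen in place of methyl on a saturated chain carbon, two bonds along the chain from an amine nitrogen, so propyl becomes ethyl on the amine. For the measured compounds named here, the only measured step, a 3.0-fold lower number from compound 1 to compound 2 (0.48 log units; beyond the scatter), swapped both groups on the amine at once and bears on this change only loosely; no step varies the length of the propyl chain alone. A trim of one methyl from a chain is therefore expected to leave the number for compound 3 in this assay near that of compound 2, with a small weakening possible, and the step of a 1.3-fold higher number from compound 2 to compound 3 (0.12 log units; within the scatter) is expected to lie within the scatter. The estimate for compound 3 is 7 nM, in a range of 3 nM to 18 nM.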

Compound 3, inhibition constant: 16 nM
Estimate against measurement, compound 3: 2.3-fold (0.36 log units) below; low and high end bracket the measured number.
By their numbers in this assay, from the lowest: compound 2; then compounds 1 and 3 (each within the scatter of the next).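

In this assay, the single methyl lost on the saturated chain carbon, two bonds along the chain from the amine nitrogen, has a visible effect on its own: a 3.0-fold higher number from compound 2 to compound 3 (0.48 log units; beyond the scatter). The earlier step changed both amine groups at once and could not isolate this position. The step of no change at the digits printed from compound 1 to compound 3 (within the scatter) adds that (cyclobutylmethyl)(ethyl)amino and (cyclopropylmethyl)(3,3,3-trifluoropropyl)amino cannot be told apart here, and nothing shown offers a reason for either step.

From the compounds shown here alone, with cyclobutylmethyl held fixed, only ethyl and propyl can be compared, so it remains open whether a butyl chain on the amine would lower the number further or raise it again. Going by these compounds, it also remains open whether propyl in place of ethyl would give a similar step with cyclopropylmethyl as the other amine group.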